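A few compounds are considered here, and "the series" means these few. Any claim that something is new, unique, unknown or untested is made for them only; others in the source may bear on it.

Measured compounds:
Compound 1, `CC(=O)c1ccc(OCc2cccc(F)c2)cc1O`, 41.4 nM
Compound 2, `CC(=O)c1ccc(OCc2cccc(F)c2)cc1F`, 96.5 nM
Compound 3, `CC(=O)c1ccc(OCc2ccc(Cl)cc2)cc1F`, 52.9 nM

All three were tested in an assay on isolated protein for inhibition of Amine oxidase [flavin-containing] B (Homo sapiens), read by fluorescence, with a stated time of 15 min; a lower number here means a stronger inhibitor, a higher number a weaker inhibitor. Among them compound 2 gives the highest number, 96.5 nM. Its nearest neighbour is compound 3, whose value of 52.9 nM lies within the scatter of it, while compound 1, with 41.4 nM, sits beyond the scatter on the lower side. Among the compounds with values here, the one step that can be read cleanly is a 2.3-fold higher number from compound 1 to compound 2 (0.37 log units; beyond the scatter), a change on the shared core rather than on the benzyl ring.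

Compound 4, `CC(=O)c1ccc(OCc2cccc(Cl)c2)cc1F`, has not yet been tested. It differs from compound 2 by chloro in place of fluoro on an aromatic carbon. Within the data shown here, no measured step matches this change: the step from compound 1 to compound 2 concerns the core, and compound 3 differs from compound 2 in more than one place, so its value can only be set beside that of compound 2, where the two fall within the scatter of one another. With nothing directly comparable, swapping one halogen for another at that carbon is expected to move the number little. The estimated step is a 1.5-fold lower number from compound 2 to compound 4 (0.17 log units; within the scatter). Compound 4 is therefore expected to give about 65 nM in this assay, with a range from 25 nM to 170 nM.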

Compound 4, half-maximal inhibitory concentration: 13.3 nM
Compound 4: middle estimate off by 4.9-fold (0.69 log units), on the high side, and the stated range ends above it.
By their numbers in this assay, from the lowest: compound 4; then compounds 1, 3 and 2 (each within the scatter of the next, the first and the last beyond it).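

In this assay, putting chloro in place of fluoro on an aromatic carbon, meta to a large group, gives a 7.3-fold lower number from compound 2 to compound 4 (0.86 log units; beyond the scatter) and so lies beyond the usual scatter, even though the two groups match in heavy-atom count, hydrogen-bond donors and acceptors, and net charge. Within the data shown here, this shows that the number responds to which halogen sits at this carbon, something the earlier compounds could not reveal: their only readable step, a 2.3-fold higher number from compound 1 to compound 2 (0.37 log units; beyond the scatter) on the printed scale, concerns the shared core and leaves this carbon untouched. What lies behind the lower number with chloro cannot be said from the information available here.

The compounds shown leave open how other groups at this same carbon would read in this assay, for example bromo, methyl, methoxy or an amine. They also leave open whether the gain from chloro would carry over to the core of compound 1, which has hydroxy where compound 2 and compound 4 have fluoro.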